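Sulfonyl Group Swaps on a Shared Urea Core

This account rests on a few compounds, and the source may have more. Where it says the series, first, only, none or still open, it means among the compounds named here.

Compound 1 `O=C(NCc1ccc(S(=O)(=O)c2cncc(C(F)(F)F)c2)cc1)N1Cc2ccncc2C1`: 15 nM
Compound 2 `O=C(NCc1ccc(S(=O)(=O)C2CCCOC2)cc1)N1Cc2ccncc2C1`: 44 nM
Compound 3 `O=C(NCc1ccc(S(=O)(=O)C2CCN(C3COC3)CC2)cc1)N1Cc2ccncc2C1`: 31 nM

In an assay on isolated protein for inhibition of Nicotinamide phosphoribosyltransferase (Homo sapiens), read by mass spectrometry, with stated times of 15 min and 30 min (on this read-out higher numbers stand for weaker inhibition and lower numbers for stronger inhibition), compound 1 gives 15 nM, compound 2 gives 44 nM and compound 3 gives 31 nM. Compound 3 thus sits within the scatter of compound 2 and apart from compound 1, as a 1.4-fold lower number from compound 2 to compound 3 (0.15 log units; within the scatter) and a 2.1-fold higher number from compound 1 to compound 3 (0.32 log units; beyond the scatter) show. Compound 4 `O=C(NCc1ccc(S(=O)(=O)N2CCOCC2)cc1)N1Cc2ccncc2C1` differs from compound 3 only at the sulfonyl sulfur: morpholin-4-yl in place of 1-(oxetan-3-yl)piperidin-4-yl on a sulfonyl sulfur. Both earlier swaps at that position, a 2.9-fold higher number from compound 1 to compound 2 (0.47 log units; beyond the scatter) and a 2.1-fold higher number from compound 1 to compound 3 (0.32 log units; beyond the scatter), were modest, and the swap between two non-aromatic groups, a 1.4-fold lower number from compound 2 to compound 3 (0.15 log units; within the scatter), stayed within the scatter. A further non-aromatic replacement is therefore expected to move this assay little, so the step of a 1.5-fold higher number from compound 3 to compound 4 (0.16 log units; within the scatter) is expected to be small. Compound 4 is estimated at 45 nM, within 20 nM to 110 nM.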

Compound 4, half-maximal inhibitory concentration: 71 nM
Compound 4: the middle estimate sits 1.6-fold (0.20 log units) below what was measured, within the range that was stated.
By their numbers in this assay, from the lowest: compound 1; then compounds 3, 2 and 4 (each within the scatter of the next, the first and the last beyond it).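

In this assay, among the compounds shown here, the non-aromatic groups on the sulfonyl sulfur no longer all read alike: a 2.3-fold higher number from compound 3 to compound 4 (0.36 log units; beyond the scatter) is the first step among them to lie beyond the scatter, although a 1.6-fold higher number from compound 2 to compound 4 (0.21 log units; within the scatter) stays within it. Replacing 5-(trifluoromethyl)pyridin-3-yl with morpholin-4-yl gives the largest step shown at this position, a 4.7-fold higher number from compound 1 to compound 4 (0.68 log units; beyond the scatter). No measurement shown here accounts for these differences. The compounds shown leave open how an open-chain amine, a carboxylic acid or a longer alkyl chain on the sulfonyl sulfur would read in this assay.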